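The source may report more compounds than this note shows. Statements on the series, on what has been measured and on what is new or still open speak of the compounds shown alone.

Measured in a functional assay on HCC827 cells (Homo sapiens) for antiproliferative activity, read by MTT assay, with a stated time of 72 h; a lower number here means a stronger inhibitor, a higher number a weaker inhibitor:
- compound 1 `CN1CCN(c2ccc(Nc3ncc4nc(Sc5ccccc5)n(C5CCOCC5)c4n3)cc2)CC1`: 42.6 nM
- compound 2 `CN(C)CCN(C)c1ccc(Nc2ncc3nc([S+]([O-])c4ccccc4)n(C4CCOCC4)c3n2)cc1`: 1330 nM

In this assay compound 2 gives 1330 nM, the higher of the two numbers, and its gap to compound 1 lies beyond the scatter. Compound 3 `CN(C)CCN(C)c1ccc(Nc2ncc3nc(Sc4ccccc4)n(C4CCOCC4)c3n2)cc1` differs from compound 2 at one place: a group of 7 heavy atoms (6 carbon, 1 sulfur; one six-membered aromatic ring of carbon only) in place of a group of 8 heavy atoms (6 carbon, 1 oxygen, 1 sulfur; one six-membered aromatic ring of carbon only), on an aromatic carbon. Phenylsulfanyl enters on an aromatic carbon of a five-membered aromatic ring. For the measured compounds named here, no measured step isolates this change. Compound 1 also carries phenylsulfanyl and gives 42.6 nM, so a lower number, beyond the scatter, is expected in this assay. The expected size is a 22-fold lower number from compound 2 to compound 3 (1.35 log units; beyond the scatter). For compound 3 the estimated value is 60 nM, with an expected range of 15 nM to 250 nM.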

Compound 3, half-maximal inhibitory concentration: 499 nM
Compound 3: middle estimate off by 8.3-fold (0.92 log units), on the low side; measured number outside the range, above it.
By their numbers in this assay, from the lowest: compound 1; then compound 3; then compound 2.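

In this assay, phenylsulfanyl in place of the oxygen-bearing sulfur group, on the aromatic carbon between two ring nitrogen atoms, gives a 2.7-fold lower number from compound 2 to compound 3 (0.43 log units; beyond the scatter), so this change counts for only a modest step. The other change is large: (2-(dimethylamino)ethyl)(methyl)amino in place of 4-methylpiperazin-1-yl gives a 12-fold higher number from compound 1 to compound 3 (1.07 log units; beyond the scatter), so in this pair the amine group weighs more than the sulfur group does. Nothing available explains either step.

Open, on these data alone, is how an amine or a methyl group on this aromatic carbon would read in this assay and whether the oxygen-bearing sulfur group gives a similar step alongside 4-methylpiperazin-1-yl.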